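The source may report more compounds than this note shows. Statements on the series, on what has been measured and on what is new or still open speak of the compounds shown alone.

Working notes on the series. In a functional assay on U-87MG ATCC cells (Homo sapiens) for antiproliferative activity (a lower number here means a stronger inhibitor, a higher number a weaker inhibitor), compound 1 (`Cc1c2c(n3c1CCNC[C@@H](C)[C@H](C)Nc1cc-3ccc1C(N)=O)CC(C)(C)CC2=O`) gives 40 nM and compound 2 (`Cc1c2c(n3c1CCN(C)C[C@@H](C)[C@H](C)Nc1cc-3ccc1C(N)=O)CC(C)(C)CC2=O`) gives 49 nM, so compound 2 cannot be told apart from compound 1. Compound 3 (`CC(=O)N1CCc2c(C)c3c(n2-c2ccc(C(N)=O)c(c2)N[C@@H](C)[C@H](C)C1)CC(C)(C)CC3=O`) carries acetyl in place of methyl on an amine nitrogen in a ring. Going by the values given here, only one measured step bears on this place, a 1.2-fold higher number from compound 1 to compound 2 (0.09 log units; within the scatter), which is methyl in place of hydrogen on that nitrogen and stays within the scatter. That step shows that methyl and hydrogen there give values that cannot be separated, but no acetyl has been measured at this place, so the direction remains uncertain. In this assay the expected change is modest, a 1.6-fold higher number from compound 2 to compound 3 (0.21 log units; within the scatter), toward a higher number. For compound 3 the estimated value is 80 nM, with an expected range of 25 nM to 250 nM.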

Compound 3, half-maximal inhibitory concentration: 24 nM
Beside the measured number, compound 3's estimate is 3.3-fold (0.52 log units) above it; the whole stated range lies above it.
By their numbers in this assay, from the lowest: compounds 3, 1 and 2 (each within the scatter of the next, the first and the last beyond it).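

In this assay, going by these compounds alone, this nitrogen accepts acetyl without loss, and replacing methyl with acetyl gives a 2.0-fold lower number from compound 2 to compound 3 (0.31 log units; beyond the scatter), the first step at this place to pass the scatter, though only modestly. Against the unsubstituted nitrogen the same group gives a 1.7-fold lower number from compound 1 to compound 3 (0.22 log units; within the scatter), so acetyl can be told apart from methyl here but not from hydrogen, and all three groups fall in a narrow band of values. No measured evidence bears on why acetyl differs from methyl at this nitrogen.

Going by these compounds, whether the difference from methyl depends on the carbonyl or on the larger group stays open, and ethyl, propanoyl or methanesulfonyl on this nitrogen would separate those readings. Also open, on these data alone, is whether a longer acyl chain keeps the values in this band.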